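The source may hold more compounds than are shown below. What is called first, only, known or untested is meant among the compounds shown, and "the series" means these compounds.

Measured compounds in a physicochemical assay for solubility, read by spectrophotometry, in phosphate buffer, with a stated time of 2 h, at pH 7.4; a higher number here means a more soluble compound, a lower number a less soluble compound:

Compound 1, `COc1ccc2[nH]c(C(=O)N3CC(=O)N(Cc4ccoc4)[C@@H](Cc4ccccc4)C3)cc2c1`, gives 63600 nM.
Compound 2, `COc1ccc2[nH]c(C(=O)N3CC(=O)N(Cc4cccc(OC)n4)[C@@H](Cc4ccccc4)C3)cc2c1`, gives 47500 nM.
Compound 3, `COc1ccc2[nH]c(C(=O)N3CC(=O)N(c4ccccc4)[C@@H](Cc4ccccc4)C3)cc2c1`, gives 36100 nM.

All three share one core and differ only in the group on an amide-type nitrogen in a ring. Compound 3 has the lowest of the three numbers, but the step of a 1.3-fold lower number from compound 2 to compound 3 (0.12 log units; within the scatter) and the step of a 1.8-fold lower number from compound 1 to compound 3 (0.25 log units; within the scatter) show that nothing separates the three beyond the ordinary spread of repeat runs, and the step of a 1.3-fold lower number from compound 1 to compound 2 (0.13 log units; within the scatter) says the same.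

Compound 4, `COc1ccc2[nH]c(C(=O)N3CC(=O)N(Cc4cc5ccccc5[nH]4)[C@@H](Cc4ccccc4)C3)cc2c1`, has not been measured in this assay. It differs from compound 3 in one place: (1H-indol-2-yl)methyl in place of phenyl on an amide-type nitrogen in a ring. The earlier steps shown here swapped small groups at this same nitrogen and each stayed within the scatter; the step to compound 4 brings in a larger group and so has no close match among them. On that basis the expectation for compound 4 is a modest move downward that may well stay within the scatter, a 1.8-fold lower number from compound 3 to compound 4 (0.26 log units; within the scatter), giving an expected value of 20000 nM with a range from 7000 nM to 50000 nM.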

Compound 4, solubility: 11000 nM
For compound 4 the middle estimate is 1.8-fold (0.26 log units) above the measured one, within the range that was stated.
By their numbers in this assay, from the lowest: compound 4; then compounds 3, 2 and 1 (each within the scatter of the next).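

In this assay, for the compounds shown here, the amide-type nitrogen in a ring no longer looks like a place where every swap stays within the scatter: (1H-indol-2-yl)methyl in place of phenyl gives a 3.3-fold lower number from compound 3 to compound 4 (0.52 log units; beyond the scatter) and is the first change here to pass beyond it. The comparisons with the other two compounds point the same way, with a 4.3-fold lower number from compound 2 to compound 4 (0.64 log units; beyond the scatter) and also a 5.8-fold lower number from compound 1 to compound 4 (0.76 log units; beyond the scatter), so compound 4 stands apart from all three earlier compounds, which could not be told apart from one another. Nothing available here explains why this group lowers the number.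

The compounds shown leave open whether the fall follows the added ring or the hydrogen on the ring nitrogen of the indole, a question that a (1-methyl-1H-indol-2-yl)methyl group or a naphthalen-2-ylmethyl group at the same nitrogen could help to settle. They also leave open how a group carrying an amine or a carboxylic acid at this nitrogen would read in this assay.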